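The source may report more compounds than this note shows. Statements on the series, on what has been measured and on what is new or still open speak of the compounds shown alone.

Three amides sharing one core have been measured in an ADME assay on Vero cells (Chlorocebus sabaeus) for cytotoxicity, read by MTT assay, with a stated time of 48 h; on this read-out higher numbers stand for lower toxicity in this test and lower numbers for higher toxicity in this test. Compound 2 `CC(NC(=O)c1ccc([N+](=O)[O-])o1)c1ccccc1` gives 24000 nM, the highest of the two plain numbers in this assay. Compound 1 `O=C(NCc1ccccc1Cl)c1ccc([N+](=O)[O-])o1` gives 11000 nM, and the gap from compound 1 up to compound 2 lies beyond the scatter. Compound 3 `CC(C)(NC(=O)c1ccc([N+](=O)[O-])o1)c1ccccc1` reaches only a limit of the assay, > 180000 nM. The change from compound 2 to compound 3 is a methyl in place of a hydrogen on the carbon that carries the amide nitrogen and the aromatic ring, and it gives an at least 7.5-fold higher number from compound 2 to compound 3 (0.87 log units; beyond the scatter); this step is known only as a lower bound because of the limit of > 180000 nM in this assay, at which 1 of the 3 values shown sits.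

Compound 4 `O=C(NC(c1ccccc1)C1CC1)c1ccc([N+](=O)[O-])o1` differs from compound 2 by cyclopropyl in place of methyl on a saturated chain carbon bound to an amide-type nitrogen and an aromatic carbon, so the same carbon is again made more crowded, now by a three-membered carbon ring rather than by a second methyl. Within the data shown here, the step from compound 2 to compound 3 is the only measured step that bears on this and it raised the number at least modestly. A rise of similar size is therefore expected, as a 2.5-fold higher number from compound 2 to compound 4 (0.40 log units; beyond the scatter). Compound 4 is estimated at 60000 nM, within a range from 22000 nM to 180000 nM, with a real chance that this assay again reports only a limit.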

Compound 4, half-maximal cytotoxic concentration: 22000 nM
For compound 4 the middle estimate is 2.7-fold (0.44 log units) above the measured one, and the stated range covers the measured number.
By their numbers in this assay, from the lowest: compounds 1, 4 and 2 (each within the scatter of the next, the first and the last beyond it). At a limit, above all of these: compound 3.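

On the saturated chain carbon bound to an amide-type nitrogen and an aromatic carbon, cyclopropyl in place of methyl gives a 1.1-fold lower number from compound 2 to compound 4 (0.04 log units; within the scatter) in this assay, so on this read-out the position accepts the three-membered ring without a difference that can be told from the scatter. The earlier step, an at least 7.5-fold higher number from compound 2 to compound 3 (0.87 log units; beyond the scatter), is not matched by this change, which shows that more carbon on this position does not by itself go with a higher number; compound 3 has no hydrogen left on that carbon, whereas compound 4 keeps one. How large the earlier step really is stays unknown, so the two changes can be set side by side only in part: the limit of > 180000 nM in this assay, at which 1 of the 4 values shown sits.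

From the compounds shown here alone, whether the loss of that hydrogen is what separates the two results stays open, and a compound carrying both methyl and cyclopropyl on this carbon would bear on it. Also open, going by these compounds, is how this assay responds on this position to a longer chain such as ethyl, or to an amine or a carboxylic acid.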